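Pyrimidin-2-yl for oxazol-5-yl on the compound 1 core

A few compounds are considered here, and "the series" means these few. Any claim that something is new, unique, unknown or untested is made for them only; others in the source may bear on it.

Compound 1 `c1ccc(-c2cnco2)c(NCC2=NCCN2)c1` carries a 1,3-oxazol-5-yl group on its aromatic core. In a functional assay for activation of Alpha-1A adrenergic receptor (Homo sapiens), read by calcium flux (on this read-out lower numbers stand for an effect already at smaller amounts and higher numbers for an effect only at larger amounts of compound), compound 1 gives 17.4 nM, the lowest number of the three measured compounds. Compound 2 `Cc1ncc(-c2ccccc2NCC2=NCCN2)o1` gives 110 nM and compound 3 `Cc1nc(-c2ccccc2NCC2=NCCN2)no1` gives 724 nM. The step of a 6.3-fold higher number from compound 1 to compound 2 (0.80 log units; beyond the scatter) is a modest move, while the step of a 42-fold higher number from compound 1 to compound 3 (1.62 log units; beyond the scatter) is large; between the two substituted analogues the step of a 6.6-fold higher number from compound 2 to compound 3 (0.82 log units; beyond the scatter) is again modest.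

The unmeasured compound 4 `c1cnc(-c2ccccc2NCC2=NCCN2)nc1` differs from compound 1 by pyrimidin-2-yl in place of 1,3-oxazol-5-yl on an aromatic carbon. Within the data shown here, the nearest precedent is the change from compound 1 to compound 3, where a different five-membered aromatic ring with two hetero atoms replaced the 1,3-oxazol-5-yl and the number rose by a 42-fold higher number from compound 1 to compound 3 (1.62 log units; beyond the scatter). Compound 4 instead brings in a six-membered ring with two hetero atoms, so that step is a guide only in direction, not in size.

For compound 4 in this assay a higher number than for compound 1 is therefore expected, with an estimated step of an 8.6-fold higher number from compound 1 to compound 4 (0.94 log units; beyond the scatter). The expected value for compound 4 is 150 nM, in the range from 40 nM to 600 nM.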

Compound 4, half-maximal effective concentration: 10 nM
Estimate against measurement, compound 4: 15-fold (1.18 log units) above, and the stated range ends above it.
By their numbers in this assay, from the lowest: compounds 4 and 1 (each within the scatter of the next); then compound 2; then compound 3.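

At this place on the aromatic ring, pyrimidin-2-yl stands in for 1,3-oxazol-5-yl in this assay with no readable change (a 1.7-fold lower number from compound 1 to compound 4 (0.24 log units; within the scatter)), so a six-membered aromatic ring is tolerated here and a five-membered one is not required. Among these compounds, the two rings that carry a methyl stand well apart from pyrimidin-2-yl (an 11-fold lower number from compound 2 to compound 4 (1.04 log units; beyond the scatter); a 72-fold lower number from compound 3 to compound 4 (1.86 log units; beyond the scatter)), which shows that the large rise seen with the 5-methyl-1,2,4-oxadiazol-3-yl group does not hold for every replacement of the 1,3-oxazol-5-yl group; across these four compounds, the two unmethylated rings give the low numbers and the two methylated rings the higher ones, with no compound going against this. Nothing at hand bears on why the steps take these sizes.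

Still open, going by these compounds, is whether a methyl on the pyrimidin-2-yl ring would raise the number as it does on the oxazole (a 6.3-fold higher number from compound 1 to compound 2 (0.80 log units; beyond the scatter)), which would separate the effect of the methyl from that of the ring. Equally open, on these data alone, is whether a pyridin-2-yl or a plain phenyl ring at this place, or an amino or methoxy group on the pyrimidin-2-yl ring, would keep the number in the range of compound 4.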